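Nitro to Fluoro at the Same Aromatic Carbon

A few compounds are considered here, and "the series" means these few. Any claim that something is new, unique, unknown or untested is made for them only; others in the source may bear on it.

Three compounds share one core and differ only in the group on an aromatic carbon para to a large group. In a functional assay on SGC-7901 cells (Homo sapiens) for antiproliferative activity, read by MTT assay, with a stated time of 72 h (a lower number here means a stronger inhibitor, a higher number a weaker inhibitor), compound 1 `COc1cc(-n2cnc3ccc(-c4ccc([N+](=O)[O-])cc4)cc32)cc(OC)c1OC` gives 79 nM, the lowest of the three numbers. Compound 2 `COc1cc(-n2cnc3ccc(-c4ccc(C)cc4)cc32)cc(OC)c1OC` gives 200 nM and compound 3 `COc1cc(-n2cnc3ccc(-c4ccc(Cl)cc4)cc32)cc(OC)c1OC` gives 1270 nM; the steps of a 2.5-fold higher number from compound 1 to compound 2 (0.40 log units; beyond the scatter) and a 16-fold higher number from compound 1 to compound 3 (1.21 log units; beyond the scatter) show that both replacements of the nitro group weaken inhibition, the chloro change most. Compound 4 `COc1cc(-n2cnc3ccc(-c4ccc(F)cc4)cc32)cc(OC)c1OC` carries the change (fluoro in place of nitro on an aromatic carbon). The step of a 16-fold higher number from compound 1 to compound 3 (1.21 log units; beyond the scatter) bears most directly on it, as another halogen at the same carbon, while a 2.5-fold higher number from compound 1 to compound 2 (0.40 log units; beyond the scatter) marks the smaller end. Compound 4 is therefore expected to lose potency, a 5.1-fold higher number from compound 1 to compound 4 (0.70 log units; beyond the scatter), with an estimated 400 nM in a range of 120 nM to 1300 nM.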

Compound 4, half-maximal inhibitory concentration: 3500 nM
Compound 4: the middle estimate sits 8.8-fold (0.94 log units) below what was measured; the whole stated range lies below it.
By their numbers in this assay, from the lowest: compound 1; then compound 2; then compound 3; then compound 4.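

In this assay, among these compounds, this position proves more sensitive than the earlier compounds showed: fluoro costs more than either earlier replacement of nitro (a 44-fold higher number from compound 1 to compound 4 (1.65 log units; beyond the scatter)), and compound 4 has the highest number of the four. The two halogens also differ (a 2.8-fold higher number from compound 3 to compound 4 (0.44 log units; beyond the scatter)), so chloro does not predict fluoro here, and methyl is clearly better tolerated than fluoro (an 18-fold higher number from compound 2 to compound 4 (1.24 log units; beyond the scatter)). The compounds shown leave open how an amine, a carboxylic acid or a methoxy group at this carbon would rank against nitro. No measurement given here accounts for this order.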